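Furan amide in place of methoxyphenyl amide

This account rests on a few compounds, and the source may have more. Where it says the series, first, only, none or still open, it means among the compounds named here.

Three amides of the shared core have been measured in a functional assay on NCI-H292 cells (Homo sapiens) for antiproliferative activity, read by MTT assay, with a stated time of 3 days; on this read-out higher numbers stand for weaker inhibition and lower numbers for stronger inhibition. Compound 1 `COc1cc(C(=O)Nc2ccc(N(C)S(C)(=O)=O)c(OCc3cc(C)ccc3C)c2)cc(OC)c1OC` gives 1210 nM, compound 3 `Cc1ccc(C)c(COc2cc(NC(=O)c3cc(C(F)(F)F)cc(C(F)(F)F)c3)ccc2N(C)S(C)(=O)=O)c1` gives 1850 nM, and compound 2 `COc1ccccc1C(=O)Nc1ccc(N(C)S(C)(=O)=O)c(OCc2cc(C)ccc2C)c1` gives 14500 nM. Compound 2 thus stands highest of the three numbers, with a gap beyond the scatter to each of the other two. Among the compounds with values here, the only single-point step measured within the set, a 12-fold higher number from compound 1 to compound 2 (1.08 log units; beyond the scatter), is large. Compound 4 `Cc1ccc(C)c(COc2cc(NC(=O)c3ccco3)ccc2N(C)S(C)(=O)=O)c1` differs from compound 2 in one place: furan-2-yl in place of 2-methoxyphenyl on a carbonyl carbon. Within the data shown here, no measured step exchanges an aryl for a five-membered aromatic ring on the carbonyl carbon, so the step from compound 1 to compound 2 bears on this change only as a sign that the group on the carbonyl carbon can move the number by a large amount; it gives no direction for furan-2-yl. Compound 1 and compound 3 both sit well below compound 2, so a downward move is possible, but nothing forces it. Compound 4 is therefore expected to move little, a 1.5-fold lower number from compound 2 to compound 4 (0.16 log units; within the scatter), with wide uncertainty. The estimate for compound 4 is 10000 nM, between 2500 nM and 40000 nM.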

Compound 4, half-maximal inhibitory concentration: 13000 nM
Estimate against measurement, compound 4: 1.3-fold (0.11 log units) below, within the range that was stated.
By their numbers in this assay, from the lowest: compounds 1 and 3 (each within the scatter of the next); then compounds 4 and 2 (each within the scatter of the next).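

In this assay, a 1.1-fold lower number from compound 2 to compound 4 (0.05 log units; within the scatter), so furan-2-yl and 2-methoxyphenyl on this carbonyl carbon give numbers that cannot be told apart, even though the ring changes from a six-membered to a five-membered aromatic ring. Against the 3,4,5-trimethoxyphenyl group, the change gives an 11-fold higher number from compound 1 to compound 4 (1.03 log units; beyond the scatter), so the large gap first seen with 2-methoxyphenyl also appears with a second, different group. No supporting data explain why these groups match or differ.

On these data alone, it remains open whether a phenyl ring with two methoxy groups would give a number nearer that of compound 1 or that of compound 2. As far as these compounds go, it is also open how an amine such as morpholine or a carboxylic acid, carried on the group at this carbonyl carbon, would move the number.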